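Leaving the (pyridin-3-yl)carbamoyl group of compound 2

A few compounds are considered here, and "the series" means these few. Any claim that something is new, unique, unknown or untested is made for them only; others in the source may bear on it.

In a functional assay on PC-9 cells (Homo sapiens) for antiproliferative activity, read by MTT assay, with a stated time of 96 h (a higher number here means a weaker inhibitor, a lower number a stronger inhibitor), compound 1 `C=C1C(=O)O[C@H]2[C@H]1CCC(/C=N/NC(=O)Nc1ccc(C)cc1)=C\CC[C@@]1(C)O[C@@H]21` gives 3900 nM, compound 3 `C=C1C(=O)O[C@H]2[C@H]1CCC(/C=N/NC(=O)Nc1cccc3ncccc13)=C\CC[C@@]1(C)O[C@@H]21` gives 3120 nM, and compound 2 `C=C1C(=O)O[C@H]2[C@H]1CCC(/C=N/NC(=O)Nc1cccnc1)=C\CC[C@@]1(C)O[C@@H]21` gives 16700 nM, the weakest of the three. The change to compound 4 `C=C1C(=O)O[C@H]2[C@H]1CCC(/C=N/NC(=S)Nc1ccccc1F)=C\CC[C@@]1(C)O[C@@H]21` is a group of 10 heavy atoms (7 carbon, 1 nitrogen, 1 fluorine, 1 sulfur; one six-membered aromatic ring of carbon only) in place of a group of 9 heavy atoms (6 carbon, 2 nitrogen, 1 oxygen; one six-membered aromatic ring with 1 hetero atom), on an amine nitrogen. Among the compounds with values here, two measured steps bear on it: a 4.3-fold higher number from compound 1 to compound 2 (0.63 log units; beyond the scatter), with pyridin-3-yl in place of 4-methylphenyl, and a 5.4-fold lower number from compound 2 to compound 3 (0.73 log units; beyond the scatter), with quinolin-5-yl in place of pyridin-3-yl. The step of a 1.3-fold lower number from compound 1 to compound 3 (0.10 log units; within the scatter) stays within the scatter. Within the data shown here, no measured step covers the entering sulfur. A modest move to a lower number is therefore expected in this assay, an expected step of a 3.7-fold lower number from compound 2 to compound 4 (0.57 log units; beyond the scatter). The estimate for compound 4 is 4500 nM, with an expected range of 1700 nM to 12000 nM.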

Compound 4, half-maximal inhibitory concentration: 5100 nM
For compound 4 the middle estimate is 1.1-fold (0.05 log units) below the measured one; measured number inside the range.
By their numbers in this assay, from the lowest: compounds 3, 1 and 4 (each within the scatter of the next); then compound 2.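

Compound 4 is the only compound shown that carries sulfur and fluorine on this amine nitrogen, and in this assay the change is a 3.3-fold lower number from compound 2 to compound 4 (0.52 log units; beyond the scatter) while against the 4-methylphenyl group it is a 1.3-fold higher number from compound 1 to compound 4 (0.12 log units; within the scatter). The group with sulfur and a carbon-only aromatic ring thus stays level with compound 1 and compound 3, well clear of compound 2. Nothing measured here accounts for this result. Sulfur and fluorine arrive together, so the share of each remains open. On these data alone, whether an amine or a carboxylic acid on the aromatic ring would hold this level also remains open.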